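Protein binding notes: pyridin-2-yl for 1H-pyrazol-1-yl

The source may report more compounds than this note shows. Statements on the series, on what has been measured and on what is new or still open speak of the compounds shown alone.

Measured so far in an ADME assay on a cell-free system (plasma, Mus musculus) for protein binding, read by LC-MS, using ultracentrifugation, with a stated time of 4.2 h, tested at 1000 ng/mL:
- compound 1 `O=C(NNS(=O)(=O)c1ccccc1F)c1cc(F)cc(-n2cccn2)c1`: 98.9%
- compound 2 `O=C(NNS(=O)(=O)c1ccccc1F)c1cc(F)cc(-c2ccccn2)c1`: 98.5%
- compound 3 `Cc1cc(-n2cccn2)cc(C(=O)NNS(=O)(=O)c2ccccc2)c1F`: 99.2%

All three measured compounds sit at the high end of the scale in this assay, and none of the gaps between them exceeds the usual scatter. Compound 3 has the lowest unbound fraction of the three, but its distance to compound 1 and to compound 2 is within the scatter, so no order among them can be claimed.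

For the measured compounds named here, the one structural change that recurs here is pyridin-2-yl in place of 1H-pyrazol-1-yl on an aromatic carbon. Between the two measured compounds it gave a 1.4-fold higher unbound fraction from compound 1 to compound 2 (0.13 log units; within the scatter).

Compound 4 `Cc1cc(-c2ccccn2)cc(C(=O)NNS(=O)(=O)c2ccccc2)c1F` is not yet measured. It relates to compound 3 by pyridin-2-yl in place of 1H-pyrazol-1-yl on an aromatic carbon. This is the same kind of change as that from compound 1 to compound 2, but not the same: in the measured pair the place is meta to a fluoro group and meta to a large group, whereas in the new pair it is meta to a large group, meta to a methyl group and para to a fluoro group. The difference between the cores of compound 1 and compound 3 is not broken down here.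

Going by the values given here, for compound 4 in this assay, a step of about a 1.4-fold higher unbound fraction from compound 3 to compound 4 (0.14 log units; within the scatter) is expected, resting on the single measured example a 1.4-fold higher unbound fraction from compound 1 to compound 2 (0.13 log units; within the scatter), which was itself within the scatter. Compound 4 is therefore estimated at 98.9%, with a likely range from 98.3% to 99.4%.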

Compound 4, plasma protein binding in the Mus musculus assay: 99.9%
Estimate against measurement, compound 4: 11-fold (1.04 log units) (unbound fraction) above, and the stated range ends below it.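

In the Mus musculus assay, compound 3 gives 99.2% and compound 4 gives 99.9%. In the Mus musculus assay, pyridin-2-yl in place of 1H-pyrazol-1-yl on an aromatic carbon gave an 8.0-fold lower unbound fraction from compound 3 to compound 4 (0.90 log units; beyond the scatter), and the two measured pairs differ when set side by side: the same change on two cores in the Mus musculus assay, a 1.4-fold higher unbound fraction (0.13 log units; within the scatter) from compound 1 to compound 2 and an 8.0-fold lower unbound fraction (0.90 log units; beyond the scatter) from compound 3 to compound 4, 11-fold (1.04 log units) apart, beyond the scatter of two such steps

In this series, the step seen on the core of compound 1 therefore cannot be carried over as a fixed increment to the core of compound 3, although two pairs show only that the outcome differs between these two cores, not which difference between the cores is responsible, since those cores differ in more than one place. In a physicochemical assay for solubility, read by nephelometry, in phosphate buffer, measured as kinetic solubility, at pH 6.5 (on this read-out lower numbers stand for lower solubility and higher numbers for higher solubility), compound 3 gives 6.3 ug/mL and compound 4 gives 6.3 ug/mL. In the physicochemical assay, the same change on the core of compound 3 gave no change at the digits printed from compound 3 to compound 4 (within the scatter), but no such pair is shown on the core of compound 1, so nothing can be said about carrying the change across cores on that read-out.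

A third core carrying both 1H-pyrazol-1-yl and pyridin-2-yl would be needed to show whether either measured step recurs. On these data alone, it also remains open how protein binding and solubility would respond on these cores to a group of another kind at the same place, such as an amine or a carboxylic acid.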